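The source may hold more compounds than are shown below. What is called first, only, known or untested is meant among the compounds shown, and "the series" means these compounds.

Going by the values given here, compound 1 `CC(C)=CC[C@@H](OC(=O)C(Cl)(Cl)Cl)C1=CC(=O)c2c(O)ccc(O)c2C1=O` carries a trichloromethyl on a carbonyl carbon, and in an assay on HeLa cells for inhibition of DNA topoisomerase 1 (Homo sapiens) (a lower number here means a stronger inhibitor, a higher number a weaker inhibitor), compound 1 gives 115000 nM, the lowest of the three numbers measured so far. Compound 2 `C=CCC/C=C/C(=O)O[C@H](CC=C(C)C)C1=CC(=O)c2c(O)ccc(O)c2C1=O` gives 126000 nM in this assay, and compound 3 `C=CCCCCC(=O)O[C@H](CC=C(C)C)C1=CC(=O)c2c(O)ccc(O)c2C1=O` gives 250000 nM. Compound 4 `CCCCCCCCCCC(=O)O[C@H](CC=C(C)C)C1=CC(=O)c2c(O)ccc(O)c2C1=O` differs from compound 1 by decyl in place of trichloromethyl on a carbonyl carbon. Among the compounds with values here, two measured steps bear on this change, each putting a carbon chain in place of the trichloromethyl: a 1.1-fold higher number from compound 1 to compound 2 (0.04 log units; within the scatter) and a 2.2-fold higher number from compound 1 to compound 3 (0.34 log units; beyond the scatter). Both point toward a higher number, the step to compound 3 more clearly. Compound 4 is therefore expected to show a modest rise over compound 1, a step of about a 2.0-fold higher number from compound 1 to compound 4 (0.30 log units; within the scatter). The estimate for compound 4 in this assay is 230000 nM, with a range from 110000 nM to 500000 nM.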

Compound 4, half-maximal inhibitory concentration: > 625000 nM
Compound 4 was reported as a limit; the forecaster's own chance of this, stated with the estimate: 15%; middle value at least 2.7-fold (0.43 log units) away from the limit.
By their numbers in this assay, from the lowest: compounds 1, 2 and 3 (each within the scatter of the next, the first and the last beyond it). At a limit, above all of these: compound 4.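

In this assay compound 4 is a limit, not a number: the limit of > 625000 nM in this assay, at which 1 of the 4 values shown sits.
Decyl in place of trichloromethyl gives an at least 5.4-fold higher number from compound 1 to compound 4 (0.73 log units; beyond the scatter) and hexyl in place of vinyl gives an at least 2.5-fold higher number from compound 3 to compound 4 (0.39 log units; beyond the scatter) on the saturated chain, while decyl in place of hexa-1,5-dien-1-yl gives an at least 4.9-fold higher number from compound 2 to compound 4 (0.69 log units; beyond the scatter) and so places compound 4 above all three earlier compounds. On this carbonyl carbon, the long saturated chain thus raises the number clearly, which the shorter chains of compound 2 and compound 3 showed only weakly. On these data alone, how far compound 4 lies past its limit stays open, as does whether a butyl chain, or an amine or a carboxylic acid on the chain, would bring the number back toward that of compound 1.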